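The source may hold more compounds than are shown below. What is called first, only, known or untested is meant among the compounds shown, and "the series" means these compounds.

Measured compounds in an assay on HEK293 cells for inhibition of Leucine-rich repeat serine/threonine-protein kinase 2 (Homo sapiens), with a stated time of 48 h; a higher number here means a weaker inhibitor, a lower number a stronger inhibitor:
Compound 1 `Cc1c(Nc2nc(N)c3c(C#N)c(N4CCC[C@H]4C)n(C)c3n2)cnn1C`, 310 nM
Compound 2 `C[C@@H]1CCCN1c1c(C#N)c2c(N)nc(Nc3cn(C)nc3Cl)nc2n1C`, 190 nM

For the measured compounds named here, compound 2 and compound 1 sit within the scatter of each other, the one measured step being a 1.6-fold lower number from compound 1 to compound 2 (0.21 log units; within the scatter). Compound 3 `C[C@@H]1CCCN1c1c(C#N)c2c(N)nc(Nc3cn(C)nc3C(F)(F)F)nc2n1C` is compound 2 with trifluoromethyl in place of chloro on an aromatic carbon. Going by the values given here, the only step at hand varies the same position on the ring, yet it stays within the scatter and does not involve trifluoromethyl, so it offers no direct precedent. No step beyond the scatter is therefore expected; the expected step is a 1.3-fold higher number from compound 2 to compound 3 (0.12 log units; within the scatter). Compound 3 is estimated at 250 nM, with a range from 90 nM to 700 nM.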

Compound 3, half-maximal inhibitory concentration: 910 nM
The estimate for compound 3 lay 3.6-fold (0.56 log units) below the measured number; measured number outside the range, above it.
By their numbers in this assay, from the lowest: compounds 2 and 1 (each within the scatter of the next); then compound 3.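

In this assay the group on this aromatic carbon does matter: trifluoromethyl in place of chloro gives a 4.8-fold higher number from compound 2 to compound 3 (0.68 log units; beyond the scatter) and is a step beyond the scatter, which the earlier step was not. Set against the 1,5-dimethyl-1H-pyrazol-4-yl group, 1-methyl-3-(trifluoromethyl)-1H-pyrazol-4-yl gives a 2.9-fold higher number from compound 1 to compound 3 (0.47 log units; beyond the scatter) and so places compound 3 as the weaker inhibitor against both earlier compounds. No supporting data bear on why this change weakens inhibition.

Going by these compounds, how a methoxy group or an amine on this carbon would compare with chloro and trifluoromethyl remains open. Also open, on these data alone, is whether the step from chloro to trifluoromethyl holds with a different group on the rest of the shared core.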